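The source may hold more compounds than are shown below. What is called first, only, known or untested is meant among the compounds shown, and "the series" means these compounds.

Compound 2 `COC(=O)NC[C@H]1CN(c2ccc(-n3cc(-c4ccccn4)cn3)c(F)c2)C(=O)O1` stands at the low end of the pair measured so far: in a physicochemical assay for lipophilicity, read by HPLC, measured as octanol-water partition (on this read-out higher numbers stand for higher lipophilicity and lower numbers for lower lipophilicity), compound 2 gives 2.03, while compound 1 `O=C(OC[C@H]1CN(c2ccc(-n3cc(-c4ccccn4)cn3)c(F)c2)C(=O)O1)c1ccccc1` gives 4.21. For the measured compounds named here, the only step available, a number 2.18 log units lower from compound 1 to compound 2 (beyond the scatter), came from exchanging benzoyloxy for (methoxycarbonyl)amino on a saturated chain carbon bound to a saturated ring carbon, which sets the scale of what a swap of the side group can do.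

Compound 3 `CONC(=O)[C@H]1CN(c2ccc(-n3cc(-c4ccccn4)cn3)c(F)c2)C(=O)O1` is the next entry. The change is methoxycarbamoyl in place of ((methoxycarbonyl)amino)methyl on a saturated ring carbon. Going by the values given here, no measured step covers this exchange; the one step to hand concerns a different pair of groups, so it bears on the present change only as a reminder that the side group, not the shared core, drives the spread of numbers. With the entering group and the leaving group matched in the donors and acceptors counted, and the leaving group the larger of the two, the step from compound 2 to compound 3 is expected to be small, probably a slight fall of about a number 0.28 log units lower from compound 2 to compound 3 (within the scatter). Compound 3 is accordingly expected to give 1.75, within 1.2 to 2.3.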

Compound 3, partition coefficient: >= 1.58
Compound 3 was reported as a limit (the forecaster's own chance of this, stated with the estimate: 2%); the middle value lies beyond the limit too.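

In this assay, for the compounds shown here, compound 3 is reported only as a limit, >= 1.58, and no step from compound 1 or compound 2 to compound 3 can be read. The compounds shown leave open how far the read-out shifts when methoxycarbamoyl takes the place of ((methoxycarbonyl)amino)methyl on a saturated ring carbon, and in which direction.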